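Replacing 3-chlorophenyl with 4-methylphenyl on compound 2

The source may hold more compounds than are shown below. What is called first, only, known or untested is meant among the compounds shown, and "the series" means these compounds.

Of the compounds shown here, three have been tested in a functional assay on HCT-116 cells (Homo sapiens) for cytotoxicity, read by MTT assay, with a stated time of 72 h; on this read-out higher numbers stand for weaker inhibition and lower numbers for stronger inhibition. Compound 1 `COc1cc2nc(Cc3ccccc3Cl)[nH]c(=O)c2cc1OC` gives 9000 nM in this assay. Compound 2 `COc1cc2nc(-c3cccc(Cl)c3)nc(N=[N+]=[N-])c2cc1OC` gives 10000 nM, and compound 3 `COc1ccc(-c2nc(N=[N+]=[N-])c3cc(OC)c(OC)cc3n2)cc1` gives 10000 nM. All three numbers lie within the usual scatter of one another, so none of them can be set apart from the rest: compound 2 and compound 3 share the same figure at the digits shown, and compound 1 gives a figure that cannot be told from theirs.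

The new compound, compound 4 `COc1cc2nc(-c3ccc(C)cc3)nc(N=[N+]=[N-])c2cc1OC`, differs from compound 2 in one place: 4-methylphenyl in place of 3-chlorophenyl on an aromatic carbon. Among the compounds with values here, one measured step bears on this change. In the step of no change at the digits printed from compound 2 to compound 3 (within the scatter), a different group took the place of the same 3-chlorophenyl at the same position, and the number did not move beyond the scatter. That single step, together with the flat spread of the three measured numbers, gives no reason to expect a shift here. Compound 4 is therefore expected to sit at about 10000 nM, with a range from 5000 nM to 20000 nM. The expected step of no change at the digits printed from compound 2 to compound 4 (within the scatter) amounts to no change beyond the scatter.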

Compound 4, half-maximal inhibitory concentration: 8000 nM
Compound 4: the middle estimate sits 1.3-fold (0.10 log units) above what was measured, within the range that was stated.
By their numbers in this assay, from the lowest: compounds 4, 1, 2 and 3 (each within the scatter of the next).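

In this assay, the step of a 1.3-fold lower number from compound 2 to compound 4 (0.10 log units; within the scatter) shows that a second replacement for 3-chlorophenyl, on the aromatic carbon between two ring nitrogen atoms, also leaves the number inside the scatter, and this time the entering group is 4-methylphenyl, which is built of carbon alone. The other new comparison, a 1.3-fold lower number from compound 3 to compound 4 (0.10 log units; within the scatter) with methyl in place of methoxy on an aromatic carbon, adds a direct look at the substituent on the phenyl ring itself, and it too shows no difference that can be told from the scatter. The three aryl groups now compared at this position therefore cannot be set apart in this cell assay, and nothing available here offers an explanation for that flatness.

Still open, as far as these compounds go, is whether an amine or a carboxylic acid on this phenyl ring, or a longer chain in place of the whole ring, would move the number beyond the scatter. From the compounds shown here alone, the azido group also stays the same in compounds 2, 3 and 4, so what an amine at that carbon would do remains unknown.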